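The source may hold more compounds than are shown below. What is called first, only, known or untested is meant among the compounds shown, and "the series" means these compounds.

Measured so far:
Compound 1 `CS(=O)(=O)CCCn1c(Cn2c(=O)n(C3CN(S(C)(=O)=O)C3)c3ccncc32)cc2cc(Cl)ccc21` in an ADME assay on HeLa cells (Homo sapiens) for cytotoxicity, read by ATP content, with a stated time of 3 days; a lower number here means that less compound is tolerated, a higher number that more compound is tolerated: > 50000 nM
Compound 2 `O=c1n(Cc2cc3cc(Cl)ccc3n2CCCCO)c2cnccc2n1C1CC1` in this assay: compound 2 gives > 50000 nM

The reading of compound 1 in this assay is only a limit of the assay, > 50000 nM. Compound 2 likewise gives only a limit, > 50000 nM. Both readings sit at the same ceiling, as the limit of > 50000 nM in this assay, at which 2 of the 2 values shown sit, shows, so no real difference between them can be stated. Compound 3 `CS(=O)(=O)CCCn1c(Cn2c(=O)n(CC3CC3)c3ccncc32)cc2cc(Cl)ccc21` differs from compound 1 by cyclopropylmethyl in place of 1-(methylsulfonyl)azetidin-3-yl on an aromatic nitrogen. Going by the values given here, no measured step between two compounds is available to guide this change, so no shift beyond the usual scatter is expected; the expected step is a number no higher from compound 1 to compound 3 (the limit leaves the size open). Compound 3 is therefore estimated at 50000 nM, with a range from 20000 nM to 100000 nM, and most likely again reported only as a limit.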

Compound 3, half-maximal cytotoxic concentration: > 50000 nM
Compound 3: only a limit was reported; the forecaster's own chance of this, stated with the estimate: 75%; the middle value lies on the limit itself.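

No step can be read from compound 1 to compound 3, as both readings stop at the same ceiling: the limit of > 50000 nM in this assay, at which 3 of the 3 values shown sit.

The compounds shown leave open at what concentration any of them would become cytotoxic, and whether cyclopropylmethyl in place of 1-(methylsulfonyl)azetidin-3-yl changes that concentration at all.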